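Removing the seven-membered ring from a racemic melanocortin agonist

The source may hold more compounds than are shown below. What is called first, only, known or untested is meant among the compounds shown, and "the series" means these compounds.

Compound 2 `O=C1[C@@H](Cc2n[nH]c3ccccc23)C(=O)N(c2ccccc2)C=CN1CC(=O)N1CCCCc2ccccc21` is drawn with a defined configuration at its saturated ring carbon, and in a functional assay on CHO cells for agonist activity at Melanocortin receptor 4 (Homo sapiens), read by a luciferase reporter, with a stated time of 4 h (a higher number here means that more compound is needed for the effect, a lower number that less compound is needed), compound 2 gives 100 nM. Compound 3 `O=C1C(Cc2n[nH]c3ccccc23)C(=O)N(c2ccccc2)C=CN1CC(=O)N1CCCCc2ccccc21` has the same atoms and bonds but is drawn without that configuration: the two compounds have the same atoms and bonds; at least one stereo element is drawn with a configuration in one of them and without one in the other: 1 of 1 stereo elements differ; a stereocentre at a saturated ring carbon is drawn R in compound 2 and without a configuration in compound 3. In this assay compound 3 gives 324 nM, a step of a 3.2-fold higher number from compound 2 to compound 3 (0.51 log units; beyond the scatter), which is read with the fact that one of compounds 2 and 3 is drawn with a defined configuration and the other without, at the place where they differ in mind. Compound 1 `CC(C)N(C(=O)CN1C=CN(c2ccccc2)C(=O)[C@H](Cc2n[nH]c3ccccc23)C1=O)c1ccccc1` arises from compound 2 by a change on a carbonyl carbon: a group of 10 heavy atoms (9 carbon, 1 nitrogen; one six-membered aromatic ring of carbon only) in place of a group of 11 heavy atoms (10 carbon, 1 nitrogen; one six-membered aromatic ring of carbon only, one seven-membered non-aromatic ring with 1 hetero atom), on a carbonyl carbon. In this assay compound 1 gives 1070 nM, so that change made a step of an 11-fold higher number from compound 2 to compound 1 (1.03 log units; beyond the scatter). Compound 4 `CC(C)N(C(=O)CN1C=CN(c2ccccc2)C(=O)C(Cc2n[nH]c3ccccc23)C1=O)c1ccccc1` has not yet been measured; it arises from compound 3 by the same change, at the same place: a group of 10 heavy atoms (9 carbon, 1 nitrogen; one six-membered aromatic ring of carbon only) in place of a group of 11 heavy atoms (10 carbon, 1 nitrogen; one six-membered aromatic ring of carbon only, one seven-membered non-aromatic ring with 1 hetero atom), on a carbonyl carbon. Since this change produced an 11-fold higher number from compound 2 to compound 1 (1.03 log units; beyond the scatter) when applied to compound 2, a step of similar size, an 11-fold higher number from compound 3 to compound 4 (1.03 log units; beyond the scatter), is expected in this assay. Compound 4 is therefore estimated at 3500 nM, with a likely range from 1500 nM to 8000 nM.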

Compound 4, half-maximal effective concentration: 3240 nM
Beside the measured number, compound 4's estimate is 1.1-fold (0.03 log units) above it; the range from low to high includes it.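

In this assay, putting isopropyl(phenyl)amino on the carbonyl carbon in place of the group with the seven-membered ring gave a 10-fold higher number from compound 3 to compound 4 (1.00 log units; beyond the scatter), so the change carried from one core to the other with much the same size: the same change on two cores in this assay, an 11-fold higher number (1.03 log units; beyond the scatter) from compound 2 to compound 1 and a 10-fold higher number (1.00 log units; beyond the scatter) from compound 3 to compound 4, 1.1-fold (0.03 log units) apart, within the scatter of two such steps

The two cores have the same atoms and bonds, and the pair that received the change shows a gap of its own, a 3.0-fold higher number from compound 1 to compound 4 (0.48 log units; beyond the scatter), which matches in direction the gap seen with the other group and is to be read with this in mind: the fact that one of compounds 1 and 4 is drawn with a defined configuration and the other without, at the place where they differ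

The result therefore shows transfer only between a core drawn with a defined configuration and the same core drawn without one, and it does not show that the step would hold on a core differing in its atoms or bonds.

Among these compounds, only one replacement group appears here, so it stays open how the number would move with another amine on that carbonyl carbon, such as diethylamino or morpholine. As far as these compounds go, it also stays open whether the same step would appear with the opposite configuration drawn at the saturated ring carbon.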